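The compounds below may be only part of what the source reports. "The series", "measured", "known", "first", "only" and "open" are said of these compounds alone.

Within the data shown here, compound 2 `Cc1cn2c(-c3cn[nH]c3)cnc2c(Nc2cc(Cc3nccs3)ns2)n1` is the one compound with a number in an ADME assay on the whole organism for pharmacokinetics, with Rattus norvegicus as the target, with a stated time of 6 h, at a dose of 10 mg/kg by the oral route (on this read-out higher numbers stand for higher exposure at the dose given and lower numbers for lower exposure), where compound 2 gives 1540 ng.h/mL. Among the measured compounds shown here, compound 1 `Cc1cn2c(-c3cn[nH]c3)cnc2c(Nc2cc(Cn3cccc(C)c3=O)ns2)n1` was tested too, but in this assay compound 1 gives "not determined" (no result reported), so there is no measured step between two compounds to lean on. Compound 3 `Cc1cn2c(-c3cn[nH]c3)cnc2c(Nc2cc(Cc3ncccn3)ns2)n1` carries pyrimidin-2-yl in place of 1,3-thiazol-2-yl on a saturated chain carbon bound to an aromatic carbon. With nothing measured for this kind of change, the expected step of a 1.0-fold lower number from compound 2 to compound 3 (0.01 log units; within the scatter) is taken to stay within the usual scatter, in no particular direction. On that basis compound 3 is estimated at 1500 ng.h/mL, within a range of 500 ng.h/mL to 4500 ng.h/mL.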

Compound 3, area under the concentration-time curve: 701 ng.h/mL
The estimate for compound 3 lay 2.1-fold (0.33 log units) above the measured number; measured number inside the range.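

Placed on a saturated chain carbon bound to an aromatic carbon, the ring type matters in this assay: pyrimidin-2-yl in place of 1,3-thiazol-2-yl gives a 2.2-fold lower number from compound 2 to compound 3 (0.34 log units; beyond the scatter) and so moves exposure beyond the usual scatter. The two groups count the same hydrogen-bond acceptors and no donors, so those counts alone do not settle the exposure here. No measurement shown explains this step.

A single step cannot show whether other rings at this place would follow the same direction. From the compounds shown here alone, how a plain phenyl ring or an amine there would compare remains open.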